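The source may hold more compounds than are shown below. What is called first, only, known or untested is meant among the compounds shown, and "the series" means these compounds.

Among the compounds with values here, compound 2 `OC1CCc2cccc(Nc3ncc(-c4ccc(Cl)cc4)o3)c2C1` gives 15 nM in an in vitro functional assay on cells for antagonist activity at transient receptor potential cation channel subfamily V member 1 (Homo sapiens), read by FLIPR and calcium flux (on this read-out lower numbers stand for stronger inhibition and higher numbers for weaker inhibition), the lowest of the two numbers measured so far; the nearest is compound 1 `OC1CCc2cccc(Nc3ncc(-c4ccccc4)o3)c2C1`, which in this assay gives 187 nM. Within the data shown here, the only measured step, a 12-fold lower number from compound 1 to compound 2 (1.10 log units; beyond the scatter), went with chloro in place of hydrogen on an aromatic carbon. Compound 3 `OC1CCc2cccc(Nc3ncc(Cc4ccccc4)o3)c2C1` differs from compound 2 by benzyl in place of 4-chlorophenyl on an aromatic carbon, a change that removes that chloro and at the same time replaces the directly attached ring by benzyl. Among the measured compounds shown here, the loss of the chloro alone would be expected to undo much of the drop seen from compound 1 to compound 2, while the benzyl has no counterpart among the measured compounds, so its own effect is unknown. For compound 3 the number is therefore expected to rise by roughly a 20-fold higher number from compound 2 to compound 3 (1.30 log units; beyond the scatter), to an estimated 300 nM, with a likely range from 70 nM to 1500 nM.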

Compound 3, half-maximal inhibitory concentration: 1820 nM
The estimate for compound 3 lay 6.1-fold (0.78 log units) below the measured number; the whole stated range lies below it.
By their numbers in this assay, from the lowest: compound 2; then compound 1; then compound 3.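

Benzyl in place of phenyl gives a 9.7-fold higher number from compound 1 to compound 3 (0.99 log units; beyond the scatter) in this assay, so at this position, next to the ring oxygen, moving the ring away from direct attachment weakens inhibition even with no chloro involved. The larger change, a 120-fold higher number from compound 2 to compound 3 (2.08 log units; beyond the scatter), combines that same swap with the loss of the chloro, so it cannot be divided between the two. Nothing available explains why benzyl gives the weaker inhibition.

As far as these compounds go, it remains open whether a chloro would lower the number on a benzyl ring as it did on the phenyl ring, which 4-chlorobenzyl would test. Also open, from the compounds shown here alone, is how a longer chain such as phenethyl, or a linker holding an amine or an ether oxygen, would compare at this position.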